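Series notes: isopropyl for methyl on the aromatic carbon

The compounds below may be only part of what the source reports. "The series", "measured", "known", "first", "only" and "open" are said of these compounds alone.

Of the compounds shown here, two have been measured in a functional assay on the whole organism (stomach) for inhibition, with Rattus norvegicus as the target, at a dose of 80 mg/kg; on this read-out lower numbers stand for less inhibition and higher numbers for more inhibition at the one dose given (going by the name of the read-out). Compound 1 `CC(C)c1ccc(-c2cc(=O)c3cc(C(=O)O)ccc3o2)cc1` gives 19% in this assay. Compound 2 `Cc1ccc(-c2oc3ccc(C(=O)O)cc3c(=O)c2O)cc1` gives 6% in this assay, the lower of the two numbers; compound 1 lies higher by a margin beyond the usual scatter. Within the data shown here, compound 1 and compound 2 differ from each other in more than one place, so no single step is drawn between them, and their two values show only that the pair lies apart.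

Compound 3 `CC(C)c1ccc(-c2oc3ccc(C(=O)O)cc3c(=O)c2O)cc1` is not yet measured. It arises from compound 2 by one change: isopropyl in place of methyl on an aromatic carbon. Compound 3 carries the same isopropyl as compound 1 and otherwise matches compound 2. Among the measured compounds shown here, no single-change step has been measured, so the size of this step rests on inference alone. A small rise is expected, a number 6 percentage points higher from compound 2 to compound 3 (within the scatter), which would stay within the scatter. Compound 3 is estimated at 12% in this assay, within a range from 0% to 28%.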

Compound 3, a percentage reported as inhibition, in the whole organism at one dose (the size of the read-out at that dose, not a potency): 24%
For compound 3 the middle estimate is 12 percentage points below the measured one; low and high end bracket the measured number.
By their numbers in this assay, from the lowest: compound 2; then compounds 1 and 3 (each within the scatter of the next).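

In this assay, among these compounds, isopropyl in place of methyl on an aromatic carbon, para to a large group, gives a number 18 percentage points higher from compound 2 to compound 3 (beyond the scatter) and is the first single-change step read at this position. It shows that this position responds to a change of alkyl group in the series, at least for the pair with the hydroxy group present. The second change, hydroxy in place of hydrogen on an aromatic carbon with isopropyl present in both compounds, gives a number 5 percentage points higher from compound 1 to compound 3 (within the scatter) and so separates the pair by no more than the usual variation between repeats.

As far as these compounds go, whether a tert-butyl group, a methoxy group or a longer chain at this position would carry the read-out further stays open, as does the size of the hydroxy step with methyl in place of isopropyl. No measurement at hand accounts for either step.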